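The source may hold more compounds than are shown below. What is called first, only, known or untested is meant among the compounds shown, and "the series" means these compounds.

Compound 1 `O=C(NCCCCl)Nc1ccc(I)cc1`: in a functional assay on M21 cells (Homo sapiens) for antiproliferative activity, with a stated time of 48 h (on this read-out higher numbers stand for weaker inhibition and lower numbers for stronger inhibition), compound 1 gives > 100000 nM, which is a limit of the assay and not a number.
Compound 2 `CC(C)(C)c1ccc(NC(=O)NCCCCl)cc1`: in this assay compound 2 gives 35000 nM.
Compound 3 `CCCCC(O)c1cccc(NC(=O)NC(=O)CC)c1`: in this assay compound 3 gives > 100000 nM, again a limit of the assay rather than a number.

For the measured compounds named here, compound 2 therefore stands as the only real number among the three; the other two sit at the limit of > 100000 nM in this assay, at which 2 of the 3 values shown sit. Going by the values given here, the single measured step, an at least 2.8-fold lower number from compound 1 to compound 2 (0.45 log units; beyond the scatter), concerns only the aromatic substituent and is at least modest.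

Compound 4 `CC(C)(C)c1ccc(NC(=O)CCCl)cc1` differs from compound 2 in one place: 2-chloroethyl in place of (3-chloropropyl)amino on a carbonyl carbon. Among the compounds with values here, no measured step touches this part of the molecule, so the step from compound 1 to compound 2 gives no direct guide here. With compound 2 already a weak inhibitor at 35000 nM, compound 4 is expected to remain weak. The expected step is a 1.4-fold higher number from compound 2 to compound 4 (0.15 log units; within the scatter). Compound 4 is estimated at 50000 nM, within a range from 15000 nM to 200000 nM.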

Compound 4, half-maximal inhibitory concentration: 74000 nM
Compound 4: middle estimate off by 1.5-fold (0.17 log units), on the low side, within the range that was stated.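

In this assay, for the compounds shown here, the first measured change at this end of the molecule, 2-chloroethyl in place of (3-chloropropyl)amino on the carbonyl carbon, gives a 2.1-fold higher number from compound 2 to compound 4 (0.33 log units; beyond the scatter), so this part of the molecule does affect the read-out, though only modestly. The change removes the nitrogen, and with it a hydrogen-bond donor, and also shortens the group, so this single step cannot separate those two differences. Even so, compound 4 keeps a real number rather than joining the compounds at the limit: the limit of > 100000 nM in this assay, at which 2 of the 4 values shown sit.

On these data alone, it remains open whether the nitrogen or the chain length matters more. The role of the chlorine is also unresolved, and a primary amine or a hydroxyl group at the chain end would help test it.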